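A few compounds are considered here, and "the series" means these few. Any claim that something is new, unique, unknown or untested is made for them only; others in the source may bear on it.

Three compounds share one core. Compound 1 `CC[C@H](C)[C@H](N)CN(C(=O)[C@@H]1C[C@H]1c1ccccc1Cl)c1ccc(-c2ccccc2)cc1` reaches only the limit > 25000 nM in a functional assay for agonist activity at G protein-coupled receptor 88 (Homo sapiens), read by HTRF and cAMP accumulation (a lower number here means that less compound is needed, a higher number that more compound is needed for the effect), so no number is known for it. Compound 2 `CC[C@H](C)[C@H](N)CN(C(=O)[C@@H]1C[C@H]1c1ccccc1)c1ccc(-c2ccc(C(C)(C)C)cc2)cc1` gives 750 nM, and compound 3 `CCOc1ccc(-c2ccc(N(C[C@@H](N)[C@@H](C)CC)C(=O)[C@@H]3C[C@H]3c3ccccc3)cc2)cc1` gives 90 nM, the lowest of the two numbers, the step of an 8.3-fold lower number from compound 2 to compound 3 (0.92 log units; beyond the scatter) lying beyond the scatter. Compound 4 `CC[C@H](C)[C@H](N)CN(C(=O)[C@@H]1C[C@H]1c1ccccc1)c1ccc(-c2ccc(C(=O)N(C)C)cc2)cc1` differs from compound 3 by dimethylcarbamoyl in place of ethoxy on an aromatic carbon. Within the data shown here, the only step at this position, an 8.3-fold lower number from compound 2 to compound 3 (0.92 log units; beyond the scatter), shows that the group there matters, but it does not tell which way a dimethylcarbamoyl will turn the number. The estimate for compound 4 in this assay is 300 nM, with a range from 60 nM to 1500 nM, a step of a 3.3-fold higher number from compound 3 to compound 4 (0.52 log units; beyond the scatter) expected from compound 3 to compound 4.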

Compound 4, half-maximal effective concentration: 980 nM
Compound 4: middle estimate off by 3.3-fold (0.51 log units), on the low side, within the range that was stated.
By their numbers in this assay, from the lowest: compound 3; then compounds 2 and 4 (each within the scatter of the next). At a limit, above all of these: compound 1.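

Ethoxy's low number does not carry over to every group at this position: in this assay, the change to dimethylcarbamoyl gives an 11-fold higher number from compound 3 to compound 4 (1.04 log units; beyond the scatter). Against tert-butyl, dimethylcarbamoyl gives a 1.3-fold higher number from compound 2 to compound 4 (0.12 log units; within the scatter), so these two groups cannot be told apart here, and of the three groups only ethoxy stands clearly lower. Nothing measured here explains this difference. Open, from the compounds shown here alone, is whether ethoxy's low number is particular to that group, or whether a methoxy, a longer alkoxy chain or an amine at the same place would share it.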